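A few compounds are considered here, and "the series" means these few. Any claim that something is new, unique, unknown or untested is made for them only; others in the source may bear on it.

Measured compounds:
Compound 1, `CNc1ncc2c(-c3ccc(N4CCNCC4)nc3)nn(CC3CCCC3)c2n1` — in an assay for inhibition of proto-oncogene tyrosine-protein kinase receptor Ret (Homo sapiens), read by 33P incorporation, in the presence of a further agent that is not named here (on this read-out higher numbers stand for weaker inhibition and lower numbers for stronger inhibition), compound 1 gives 50 nM.
Compound 2, `CNc1ncc2c(-c3ccc(N4CCNCC4)nc3)nn(Cc3cn(Cc4ccccc4)nn3)c2n1` — in this assay compound 2 gives 600 nM.

Compound 2 stands highest of the two numbers shown, its only neighbour being compound 1, with a 12-fold higher number from compound 1 to compound 2 (1.08 log units; beyond the scatter). That single measured step concerns a different part of the molecule: the group on the saturated chain carbon bound to an aromatic nitrogen.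

Compound 3, `CNc1ncc2c(-c3ccc(N4CCNCC4)cc3)nn(Cc3cn(Cc4ccccc4)nn3)c2n1`, has not yet been measured. It keeps the group that enters in compound 2 and differs from compound 2 in 4-(piperazin-1-yl)phenyl in place of 6-(piperazin-1-yl)pyridin-3-yl on an aromatic carbon. No measured pair among the compounds shown varies this part of the structure, so nothing here tells how large a step such a change brings. In this assay the step from compound 2 to compound 3 is therefore expected to be no change at the digits printed from compound 2 to compound 3 (within the scatter), not clearly beyond the scatter in either direction. Compound 3 is estimated at 600 nM, in a range from 200 nM to 1800 nM.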

Compound 3, half-maximal inhibitory concentration: > 10000 nM
Compound 3 gave a limit, no number (the forecaster's own chance of this, stated with the estimate: 5%); at least 16-fold (1.22 log units) between middle value and limit.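

The earlier pair varied only the group on the saturated chain carbon; this result shows that the group on the aromatic carbon also has a strong influence on the read-out. The two groups have the same count of heavy atoms and differ in one ring nitrogen giving way to carbon, yet that exchange brings an at least 16-fold higher number from compound 2 to compound 3 (1.22 log units; beyond the scatter). In this assay, on these data alone, compound 3 gives > 10000 nM, which is a limit and not a number, so the full size of the step remains unknown.

The compounds shown do not tell whether the same exchange would have a similar effect with the cyclopentyl group of compound 1. They also do not show why the ring nitrogen matters, or how a fluorine or a methoxy group on the phenyl ring of compound 3 would read.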